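Swapping chloro for trifluoromethyl on the shared core

The source may hold more compounds than are shown below. What is called first, only, known or untested is meant among the compounds shown, and "the series" means these compounds.

Compound 1 `NC(=S)N/N=C1/C(=O)N(CN2CCN(c3ccnc4cc(Cl)ccc34)CC2)c2cc(Br)ccc21` was tested in an ADME assay on MCF-10A cells (Homo sapiens) for cytotoxicity, read by sulforhodamine B assay, with a stated time of 48 h (on this read-out higher numbers stand for weaker inhibition of growth and lower numbers for stronger inhibition of growth), where compound 1 gives 22100 nM. Compound 2 `NC(=S)N/N=C1/C(=O)N(CN2CCN(c3ccnc4cc(Cl)ccc34)CC2)c2ccccc21`, which carries hydrogen in place of bromo on an aromatic carbon, gives 27700 nM in this assay. Among the two numbers measured, compound 1 holds the lower one, and the step of a 1.3-fold higher number from compound 1 to compound 2 (0.10 log units; within the scatter) shows that compound 2 lies within the scatter of it, so no order between the two can be claimed.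

Compound 3 `NC(=S)N/N=C1/C(=O)N(CN2CCN(c3ccnc4cc(C(F)(F)F)ccc34)CC2)c2cc(Br)ccc21` differs from compound 1 by trifluoromethyl in place of chloro on an aromatic carbon. Among the compounds with values here, no measured step touches this change; the single measured step, a 1.3-fold higher number from compound 1 to compound 2 (0.10 log units; within the scatter), concerns another replacement and was itself within the scatter. With nothing in the data pointing in either direction, one expects the move from compound 1 to compound 3 to stay within the scatter, which corresponds to an expected step of a 1.1-fold lower number from compound 1 to compound 3 (0.04 log units; within the scatter). Compound 3 is therefore estimated at 20000 nM in this assay, with an expected range from 8000 nM to 50000 nM.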

Compound 3, concentration for 50% growth inhibition: 27000 nM
For compound 3 the middle estimate is 1.4-fold (0.13 log units) below the measured one, and the stated range covers the measured number.
By their numbers in this assay, from the lowest: compounds 1, 3 and 2 (each within the scatter of the next).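

Within the data shown here, the step of a 1.2-fold higher number from compound 1 to compound 3 (0.09 log units; within the scatter) in this assay gives the first reading at this place, an aromatic carbon of a six-membered aromatic ring of carbon only, part of a fused or bridged system of two rings. It shows that trifluoromethyl, with 4 heavy atoms, can stand in place of chloro, with 1 heavy atom, without a step beyond the scatter. The earlier compounds had shown this only for hydrogen in place of bromo, a step of a 1.3-fold higher number from compound 1 to compound 2 (0.10 log units; within the scatter) and thus at a different place, and no measurement given here offers an explanation for either result.

The compounds shown leave open whether a group of another kind at this place, such as an amine, a carboxylic acid or a nitrile, would also stay within the scatter or would move the number beyond it. On these data alone, it also remains open whether trifluoromethyl in place of chloro would read the same on the core of compound 2, which carries hydrogen in place of bromo.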